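Working notes: 4-methoxyphenyl to 4-chlorophenyl

The source may hold more compounds than are shown below. What is called first, only, known or untested is meant among the compounds shown, and "the series" means these compounds.

Values in an ADME assay on Vero cells (Chlorocebus sabaeus) for cytotoxicity (a higher number here means that more compound is tolerated, a lower number that less compound is tolerated), follow
- compound 1 `CC(=O)c1c(Nc2ccc(F)cc2F)[nH]c2c(F)cc(F)cc2c1=O` gives > 25000 nM (a limit)
- compound 2 `COc1ccc(Nc2[nH]c3c(F)cc(F)cc3c(=O)c2C(C)=O)cc1` gives > 25000 nM (a limit)
- compound 3 `CC(=O)c1c(Nc2ccc(Cl)cc2)[nH]c2c(F)cc(F)cc2c1=O` is not yet measured

Compound 2 stands at > 25000 nM, which is a limit and not a number. Within the data shown here, the series so far shows (the limit of > 25000 nM in this assay, at which 2 of the 2 values shown sit). Compound 3 carries chloro in place of methoxy on an aromatic carbon, with chloro in place of methoxy on an aromatic carbon, para to a large group. Among the measured compounds shown here, the only measured step bearing on this is a step that the two limits leave unreadable from compound 1 to compound 2, so neither a size nor a direction can be carried over from it. The expected outcome is a number no higher from compound 2 to compound 3 (the limit leaves the size open), with no shift beyond the scatter anticipated. Compound 3 is estimated at 25000 nM, with an expected range of 12000 nM to 50000 nM.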

Compound 3, half-maximal cytotoxic concentration: > 25000 nM
Compound 3 was reported as a limit; the forecaster's own chance of this, stated with the estimate: 75%; the middle value lies on the limit itself.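

In this assay, among these compounds, compound 3 gives > 25000 nM as a limit, so no step among compound 1, compound 2 and compound 3 can be read. The compounds shown leave open whether these three differ at all in this read-out: the limit of > 25000 nM in this assay, at which 3 of the 3 values shown sit.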